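A few compounds are considered here, and "the series" means these few. Any claim that something is new, unique, unknown or untested is made for them only; others in the source may bear on it.

Measured compounds:
compound 1, `OC(CCn1nc2c(Br)c(Br)c(Br)c(Br)c2n1)c1cccc(Cl)c1`, 118%
compound 2, `C[C@@H](O)CCn1nc2c(Br)c(Br)c(Br)c(Br)c2n1`, 81%
compound 3, `OC(CCn1nc2c(Br)c(Br)c(Br)c(Br)c2n1)c1ccccc1`, 123%

All three share the same brominated core and were tested in a functional assay on CCRF-CEM cells (Homo sapiens) for antiproliferative activity, read by MTT assay, with a stated time of 24 h, tested at 25 uM; a higher number here means a weaker effect of the compound at the concentration tested, a lower number a stronger effect. Among the three numbers, compound 3 gives the highest value with 123%. Its nearest neighbour is compound 1, and the step of a number 5 percentage points higher from compound 1 to compound 3 (within the scatter) is within the usual scatter, so the two cannot be told apart. Compound 2 gives 81%, which lies well apart from compound 3, beyond the scatter.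

Compound 4, `OC(CCn1nc2c(Br)c(Br)c(Br)c(Br)c2n1)c1ccc(Cl)cc1`, has not yet been measured in this assay. The change from compound 3 is chloro in place of hydrogen on an aromatic carbon. Among the measured compounds shown here, the one measured step that involves a chloro on the aromatic ring is a number 5 percentage points higher from compound 1 to compound 3 (within the scatter), which did not move the value beyond the scatter. For the measured compounds named here, there is no step that puts the chloro at the place it takes in compound 4, so the expectation rests on compound 1 alone.

The step of a number 5 percentage points lower from compound 3 to compound 4 (within the scatter) is therefore expected to be none beyond the scatter, because a number 5 percentage points higher from compound 1 to compound 3 (within the scatter) was within it. Compound 4 is expected to give about 118%, with a range from 95% to 140%.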

Compound 4, a percentage reported as activity, at one concentration (the size of the read-out at that concentration, not a potency): 106%
The estimate for compound 4 lay 12 percentage points above the measured number; low and high end bracket the measured number.
By their numbers in this assay, from the lowest: compound 2; then compound 4; then compounds 1 and 3 (each within the scatter of the next).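

In this assay, placing a chloro on the phenyl ring, para to a large group, gives a number 17 percentage points lower from compound 3 to compound 4 (beyond the scatter), so this ring can shift the read-out after all, though only modestly. Where the chloro sits also counts: exchanging 3-chlorophenyl for 4-chlorophenyl gives a number 12 percentage points lower from compound 1 to compound 4 (beyond the scatter), while the earlier comparison of the unsubstituted phenyl with 3-chlorophenyl stayed at a number 5 percentage points higher from compound 1 to compound 3 (within the scatter). Nothing available here accounts for this difference between the two chloro compounds.

Going by these compounds, it remains open whether the shift is specific to chloro or would also appear with another group at this place, such as a methoxy group or an amine. On these data alone, it is equally open whether a group of that kind would take the number further down, towards that of the much lower compound 2 at 81%.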